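Notes on the dimethylphenyl variation in the series

The source may report more compounds than this note shows. Statements on the series, on what has been measured and on what is new or still open speak of the compounds shown alone.

Within the data shown here, in an ADME assay on RAW264.7 cells (Mus musculus) for cytotoxicity, read by MTT assay, with a stated time of 48 h, tested at 50 uM (on this read-out higher numbers stand for more inhibition at the one concentration tested (going by the name of the read-out) and lower numbers for less inhibition), compound 2 `Cc1ccc(N2C(=N)S/C(=C\c3ccc(OCc4ccccc4)cc3)C2=O)c(C)c1` gives 36.8%, the lowest of the two numbers so far. Among the measured compounds shown here, compound 1 `Cc1c(Cl)cccc1N1C(=N)S/C(=C\c2ccc(OCc3ccccc3)cc2)C1=O` gives 59.7% in this assay, and the one measured step, a number 22.9 percentage points lower from compound 1 to compound 2 (beyond the scatter), changed the whole aryl group. Compound 3 `Cc1cccc(C)c1N1C(=N)S/C(=C\c2ccc(OCc3ccccc3)cc2)C1=O` differs from compound 2 by 2,6-dimethylphenyl in place of 2,4-dimethylphenyl on an amide-type nitrogen in a ring. For the measured compounds named here, no measured step tests this kind of change, so the only guide is the modest size of the one step seen. Compound 3 is therefore expected to stay close to compound 2, with a number 5.2 percentage points higher from compound 2 to compound 3 (within the scatter) as the expected step. The estimate for compound 3 is 42%, with a range from 22% to 62%.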

Compound 3, a percentage reported as inhibition, at one concentration (the size of the read-out at that concentration, not a potency): 38.7%
Estimate against measurement, compound 3: 3.3 percentage points above, and the stated range covers the measured number.
By their numbers in this assay, from the lowest: compounds 2 and 3 (each within the scatter of the next); then compound 1.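

In this assay, 2,6-dimethylphenyl in place of 2,4-dimethylphenyl on the amide-type nitrogen gives a number 1.9 percentage points higher from compound 2 to compound 3 (within the scatter) and so shows no measurable change between these two arrangements of the same atoms. The step of a number 21 percentage points lower from compound 1 to compound 3 (beyond the scatter) places both dimethylphenyl compounds apart from the 3-chloro-2-methylphenyl of compound 1, so the earlier gap does not hang on the 2,4-dimethylphenyl group alone. No measured evidence explains either step.

Open, as far as these compounds go, is whether the chlorine itself carries the gap, since every step here changes more than that one atom. Also open, from the compounds shown here alone, is how a carboxylic acid or an amine on this aryl group would read.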